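The source may hold more compounds than are shown below. What is called first, only, known or untested is meant among the compounds shown, and "the series" means these compounds.

Compound 1 `CNCc1cn(S(=O)(=O)c2ccco2)c(-c2cccnc2F)c1F` and compound 2 `CNCc1cn(S(=O)(=O)c2cccc(OC)n2)c(-c2cccnc2F)c1F` share one core and differ only in the aryl group on the sulfonyl sulfur. In a functional assay on the whole organism (strain Jcl:Sprague-Dawley) for inhibition, with Rattus norvegicus as the target, with stated times of 3 min and 3 h, at a dose of 1 mg/kg by the intravenous route (a higher number here means more inhibition at the dose given (going by the name of the read-out), a lower number less inhibition), compound 1 gives 75%, the lower of the two numbers in hand, and compound 2 gives 98%. For the measured compounds named here, the single measured step, a number 23 percentage points higher from compound 1 to compound 2 (beyond the scatter), is the only comparison available.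

Compound 3 `CNCc1cn(S(=O)(=O)c2cncc(F)c2)c(-c2cccnc2F)c1F` has not yet been measured. It differs from compound 1 as follows (5-fluoropyridin-3-yl in place of furan-2-yl on a sulfonyl sulfur). The step from compound 1 to compound 2 bears on this change, since in both cases the furan-2-yl on the sulfonyl sulfur gives way to a six-membered aromatic ring with one hetero atom, though the entering rings are not the same. Because that step was a number 23 percentage points higher from compound 1 to compound 2 (beyond the scatter), an increase beyond the scatter, a rise in this assay is expected for compound 3 as well, though its size remains uncertain and could be smaller than the measured one. On this basis compound 3 is expected to reach 88%, within 70% to 99%. The step this estimate implies, a number 13 percentage points higher from compound 1 to compound 3 (beyond the scatter), is expected to lie beyond the scatter.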

Compound 3, a percentage reported as inhibition, in the whole organism at one dose (the size of the read-out at that dose, not a potency): 99%
Compound 3: the middle estimate sits 11 percentage points below what was measured; the range from low to high includes it.
By their numbers in this assay, from the lowest: compound 1; then compounds 2 and 3 (each within the scatter of the next).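

In this assay the change from furan-2-yl to 5-fluoropyridin-3-yl on the sulfonyl sulfur gives a number 24 percentage points higher from compound 1 to compound 3 (beyond the scatter), so a second six-membered aromatic ring with one hetero atom also stands clear of the furan compound, and the rise seen earlier is not tied to 6-methoxypyridin-2-yl alone. The exchange of one six-membered ring for the other gives a number 1 percentage points higher from compound 2 to compound 3 (within the scatter), so fluoro and methoxy substitution on these two different pyridyl groups cannot be told apart in this read-out, where both numbers lie close to the top of the percentage scale at the single dose given. No measurement in hand explains the difference between the furan-2-yl group and the two pyridyl groups.

As far as these compounds go, whether a plain phenyl ring, which has no ring nitrogen, or a methyl group on the sulfonyl sulfur would stand with compound 1 or with compounds 2 and 3 remains open. Also open, from the compounds shown here alone, is whether compounds 2 and 3 would separate at a lower dose, as one dose gives the size of the inhibition and not a potency.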